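A few compounds are considered here, and "the series" means these few. Any claim that something is new, unique, unknown or untested is made for them only; others in the source may bear on it.

Compound 1 `COC(=O)c1[nH]c2cc(OC)ccc2c1CC(C)C`: 16600 nM
Compound 2 `COC(=O)c1[nH]c2cc(OC)ccc2c1C1CCCCC1`: 80200 nM

Both values come from a functional assay on CCRF-CEM cells (Homo sapiens) for antiproliferative activity, read by MTT assay, with a stated time of 48 h; on this read-out higher numbers stand for an effect only at larger amounts of compound and lower numbers for an effect already at smaller amounts. Among the compounds with values here, compound 2 holds the higher of the two numbers, and compound 1 is its only neighbour.

Compound 3 `COC(=O)Cc1c(C(=O)OC)[nH]c2cc(OC)ccc12` is not yet measured. The change is (methoxycarbonyl)methyl in place of cyclohexyl on an aromatic carbon, next to the ring atom that bears a methoxycarbonyl group.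

Within the data shown here, one measured step bears on this: a 4.8-fold higher number from compound 1 to compound 2 (0.68 log units; beyond the scatter). There, the cyclohexyl compound carries the higher number, and the group that enters in compound 3 has no ring, like isobutyl. No chain with an ester has been measured here, so the direction is tentative. A modest move to a lower number in this assay is expected, as a 2.7-fold lower number from compound 2 to compound 3 (0.43 log units; beyond the scatter). For compound 3 the estimated value is 30000 nM, with an expected range of 10000 nM to 90000 nM.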

Compound 3, half-maximal effective concentration: > 100000 nM
Compound 3 was reported as a limit; the forecaster's own chance of this, stated with the estimate: 15%; at least 3.3-fold (0.52 log units) between middle value and limit.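

Compound 3 stands only as a limit in this assay, so every step to it is a floor: the limit of > 100000 nM in this assay, at which 1 of the 3 values shown sits.

Set against the isobutyl compound, methoxycarbonyl in place of isopropyl on the saturated chain carbon bound to the aromatic carbon gives an at least 6.0-fold higher number from compound 1 to compound 3 (0.77 log units; beyond the scatter), so having no ring does not by itself keep the number low at this position, and the ester-bearing chain differs clearly from the isobutyl chain. Set against the cyclohexyl compound, the change gives an at least 1.2-fold higher number from compound 2 to compound 3 (0.09 log units; that floor lies within the scatter), so no order between these two can be stated.

On these data alone, whether a carboxylic acid or an amine in place of the ester, or a longer chain carrying the ester, would bring the number back towards that of compound 1 stays open. As far as these compounds go, the actual value of compound 3 also stays open.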